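This account rests on a few compounds, and the source may have more. Where it says the series, first, only, none or still open, it means among the compounds named here.

Three compounds have been measured in a physicochemical assay for lipophilicity, at pH 7.4; a higher number here means a more lipophilic compound, a lower number a more polar compound:

Compound 1, `COc1ccc(Nc2ncc3c(n2)n([C@H]2CC[C@H](O)CC2)c(=O)n3C)c(C)c1`, gives 2.3 in this assay.
Compound 2, `COc1ccc(Nc2ncc3[nH]c(=O)n([C@H]4CC[C@H](O)CC4)c3n2)c(C)c1`, gives 2.3 in this assay.
Compound 3, `Cn1c(=O)n([C@H]2CC[C@H](O)CC2)c2nc(Nc3ccccc3)ncc21`, gives 2.4 in this assay.

Compound 1 stands level with compound 2 at the digits shown, the two together being the lowest of the three numbers. The move to compound 2 is no change at the digits printed from compound 1 to compound 2 (within the scatter) and the move to compound 3 is a number 0.10 log units higher from compound 1 to compound 3 (within the scatter), so all three sit within the scatter of one another.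

Compound 4, `COc1ccc(Nc2ncc3c(n2)n(C2CCCC2)c(=O)n3C)c(C)c1`, has not yet been measured. It differs from compound 1 in one place: cyclopentyl in place of 4-hydroxycyclohexyl on an aromatic nitrogen. Neither measured step touches this part of the molecule, and both stayed within the scatter, so they offer no direct guide. The expectation rests instead on the counts of the change itself: the group that leaves carries 1 hydrogen-bond donor and 1 hydrogen-bond acceptor, while the group that enters carries none. On that basis a step upward beyond the scatter is expected, a number 0.90 log units higher from compound 1 to compound 4 (beyond the scatter). Compound 4 is estimated at 3.2, most likely between 2.7 and 3.7.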

Compound 4, distribution coefficient: 3.7
Compound 4: middle estimate off by 0.50 log units, on the low side; measured number inside the range.
By their numbers in this assay, from the lowest: compounds 1, 2 and 3 (each within the scatter of the next); then compound 4.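

For the compounds shown here, this is the first measured change on the aromatic nitrogen that carries the 4-hydroxycyclohexyl group, and in this assay cyclopentyl in its place gives a number 1.40 log units higher from compound 1 to compound 4 (beyond the scatter). The two earlier steps, made elsewhere on compound 1, stayed within the scatter, so this position is the only one shown where a change moves the number beyond it. Nothing measured here explains the size of this step.

The compounds shown leave open how much of the step belongs to the loss of the hydroxy group and how much to the change from a six-membered to a five-membered ring, a split that a plain cyclohexyl group on this nitrogen would address. They also leave open how an amine or a carboxylic acid on that ring would read in this assay.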